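The source may hold more compounds than are shown below. What is called first, only, known or untested is meant among the compounds shown, and "the series" means these compounds.

Compound 1 `C=C1CCCC(C)(C)C1CC[C@]1(C)CC[C@@H]([C@@H](C)C(=O)O)OO1` was examined in a functional assay on OVCAR-8 cells (Homo sapiens) for inhibition; a higher number here means a weaker inhibitor of growth, a lower number a stronger inhibitor of growth. In this assay compound 1 gives > 10000 nM, which is a limit of the assay and not a number. Compound 2 `CC1=C(CC/C(C)=C/CC[C@@]2(C)CC[C@@H]([C@H](C)C(=O)O)OO2)C(C)(C)CCC1` was examined in the same way. In this assay compound 2 gives > 100000 nM, again a limit rather than a number. Among the measured compounds shown here, compound 1 therefore stands on a limit, and the one further value shown beside it is a limit too. Compound 1 sits at the limit of > 10000 nM in this assay, at which 1 of the 2 values shown sits. Compound 2 sits at the limit of > 100000 nM in this assay, at which 1 of the 2 values shown sits. For the measured compounds named here, no step between measured compounds is counted, so nothing here sets the size of any change.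

Going by the values given here, compound 3 `C=C1CCCC(C)(C)C1CC[C@@]1(C)CC[C@H]([C@@H](C)C(=O)O)OO1` is the compound not yet measured. the two compounds have the same atoms and bonds; at least one stereo element is drawn with a configuration in one of them and without one in the other: 2 of 4 stereo elements differ; a stereocentre at a saturated ring carbon is drawn R in compound 1 and S in compound 3; a stereocentre at a saturated ring carbon is drawn S in compound 1 and R in compound 3 The shared core is kept whole, and only two stereocentres at saturated ring carbons are drawn the other way round. Among the compounds with values here, with no measured step to lean on, the expectation for compound 3 in this assay is no movement beyond the scatter in either direction, and most likely a limit once more. Compound 3 is expected to give 10000 nM in this assay, within 3000 nM to 30000 nM. The expected step is a number no higher from compound 1 to compound 3 (the limit leaves the size open).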

Compound 3, concentration for 50% growth inhibition: > 12500 nM
Compound 3: only a limit was reported (the forecaster's own chance of this, stated with the estimate: 70%); middle value at least 1.2-fold (0.09 log units) away from the limit.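

In this assay compound 3 gives > 12500 nM and this is a limit of the assay, not a number. Among the compounds shown here, compound 1 gives > 10000 nM as a limit too, so no step between compound 1 and compound 3 can be read. The compounds shown leave open whether drawing the two stereocentres the other way round changes growth inhibition at all.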